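From compound 1 to compound 4: one added methyl

A few compounds are considered here, and "the series" means these few. Any claim that something is new, unique, unknown or untested is made for them only; others in the source may bear on it.

Compound 1, `CC(C)=CCC/C(C)=C/CC/C(C)=C/CC[C@]1(C)CCc2cc(OC(=O)NCc3ccccc3)cc(C)c2O1`: > 10000 nM
Compound 2, `CC(C)=CCC/C(C)=C/CC/C(C)=C/CC[C@]1(C)CCc2cc(OC(=O)NS(=O)(=O)c3ccccc3)cc(C)c2O1`: > 10000 nM
Compound 3, `CC(C)=CCC/C(C)=C/CC/C(C)=C/CC[C@]1(C)CCc2cc(OC(=O)NC(=O)Oc3ccccc3)cc(C)c2O1`: "not determined" (no result reported)

In a functional assay on MDA-MB-231 cells (Homo sapiens) for antiproliferative activity, read by MTT assay, with a stated time of 96 h (on this read-out higher numbers stand for weaker inhibition and lower numbers for stronger inhibition), compound 1 gives > 10000 nM, which is a limit and not a number. Compound 2 gives > 10000 nM, which is also a limit. For compound 3 the entry reads "not determined" (no result reported). Compound 1 therefore has no exact position in the series, and the data show only (the limit of > 10000 nM in this assay, at which 2 of the 3 values shown sit).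

Compound 4, `CC(C)=CCC/C(C)=C/CC/C(C)=C/CC[C@]1(C)CCc2cc(OC(=O)NCc3ccccc3)c(C)c(C)c2O1`, departs from compound 1 in one place: methyl in place of hydrogen on an aromatic carbon. One measured step exists, a step that the two limits leave unreadable from compound 1 to compound 2, with phenylsulfonyl in place of benzyl on an amide-type nitrogen. That step lies elsewhere in the structure and has no readable size to carry over. Among the measured compounds shown here, no measured step involves methyl in place of hydrogen on an aromatic carbon. The expectation in this assay is thus no step beyond the scatter, and no direction is favoured. The estimate is anchored only on compound 1 at > 10000 nM, and another limit is the likeliest report. The expected change is a step that the limit leaves unreadable from compound 1 to compound 4. Compound 4 is estimated at 15000 nM, with an expected range from 7000 nM to 40000 nM.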

Compound 4, half-maximal inhibitory concentration: > 10000 nM
Compound 4 gave a limit, no number; the forecaster's own chance of this, stated with the estimate: 85%; the middle value is on the limit's open side.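

Compound 1 and compound 4 both end at a limit rather than a number, so no step between them can be read: the limit of > 10000 nM in this assay, at which 3 of the 4 values shown sit.

The compounds shown leave open whether methyl in place of hydrogen on an aromatic carbon changes the antiproliferative activity at all, and where compound 1 and compound 4 actually stand.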